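The compounds below may be only part of what the source reports. "The series", "measured", "known", "first", "only" and "open" are said of these compounds alone.

Measured so far in a functional assay on cells for antagonist activity at C-C chemokine receptor type 4 (Homo sapiens), read by fluorescence and calcium flux, with stated times of 2.5 s and 45 s; on this read-out higher numbers stand for weaker inhibition and lower numbers for stronger inhibition:
compound 1 `Cc1nn([C@H](C)c2ccc(Cl)cc2Cl)c2nc(N3CC[C@H](N4CCC[C@H]4C(N)=O)[C@H](C)C3)cnc12` — 170 nM
compound 2 `Cc1nn([C@H](C)c2ccc(Cl)cc2Cl)c2nc(N3CC[C@@H](N4CCCCC4)[C@@H](C)C3)cnc12` — 803 nM
compound 3 `Cc1nn(C(C)c2ccc(Cl)cc2Cl)c2nc(N3CCC(N4CCCCC4)C(C)C3)cnc12` — 126 nM

Compound 3 holds the lowest of the three numbers. Compound 1 sits close to it, within the scatter, so the two are not separated on this read-out. Compound 2 lies well apart: the step of a 6.4-fold lower number from compound 2 to compound 3 (0.80 log units; beyond the scatter) is beyond the scatter, and the only thing that separates the pair is the fact that one of compounds 2 and 3 is drawn with a defined configuration and the other without, at the place where they differ, compound 2 carrying one fixed arrangement at all three stereocentres while compound 3 is drawn with none.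

Compound 4 `Cc1nn([C@H](C)c2ccc(Cl)cc2Cl)c2nc(N3CC[C@H](N4CCCCC4)[C@H](C)C3)cnc12` is the next entry. Against compound 3 the change is the two compounds have the same atoms and bonds; at least one stereo element is drawn with a configuration in one of them and without one in the other: 3 of 3 stereo elements differ; a stereocentre at a saturated chain carbon is drawn without a configuration in compound 3 and R in compound 4; a stereocentre at a saturated ring carbon is drawn without a configuration in compound 3 and S in compound 4; a stereocentre at a saturated ring carbon is drawn without a configuration in compound 3 and R in compound 4. No atom leaves or enters; the three stereocentres are simply fixed, and the configurations drawn in compound 4 are the ones also drawn in compound 1, while compound 2 carries the opposite arrangement at both ring carbons.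

Going by the values given here, the one measured step that bears on this, from compound 2 to compound 3, shows that fixing the ring configurations the other way gives a markedly higher number; compound 3 as the unfixed material therefore likely contains a component with a lower number than its own value. A modest downward step in this assay is expected, a 2.1-fold lower number from compound 3 to compound 4 (0.32 log units; beyond the scatter), not large, since compound 1 with the same drawn configurations gives 170 nM.

Compound 4 is estimated at 60 nM, with a range of 20 nM to 250 nM.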

Compound 4, half-maximal inhibitory concentration: 42 nM
Compound 4: the middle estimate sits 1.4-fold (0.15 log units) above what was measured, and the stated range covers the measured number.
By their numbers in this assay, from the lowest: compound 4; then compounds 3 and 1 (each within the scatter of the next); then compound 2.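

In this assay the two saturated ring carbons now have a measured effect of their own, with a 19-fold lower number from compound 2 to compound 4 (1.28 log units; beyond the scatter) and no change elsewhere in the structure: the fact that compounds 2 and 4 differ only in the configuration as drawn

Fixing all three stereocentres as drawn in compound 4 also gives a 3.0-fold lower number from compound 3 to compound 4 (0.48 log units; beyond the scatter), which places compound 3, drawn with no configuration, numerically inside the span set by compound 2 and compound 4: the fact that one of compounds 3 and 4 is drawn with a defined configuration and the other without, at the place where they differ

With the same configurations drawn, piperidin-1-yl in place of 2-carbamoylpyrrolidin-1-yl gives a 4.0-fold lower number from compound 1 to compound 4 (0.61 log units; beyond the scatter), so the group on that saturated ring carbon also moves the number, and the earlier comparison of compound 1 with compound 3, which fell within the scatter, did not reveal this.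

As far as these compounds go, the contribution of the saturated chain carbon stays open, as it is drawn R in both compound 2 and compound 4. Also open, from the compounds shown here alone, is how the number responds to other groups on the saturated ring carbon, such as morpholin-4-yl or 2-carboxypyrrolidin-1-yl.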